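Heteroaryl exchange on the chlorobenzamide series: compound 4

The compounds below may be only part of what the source reports. "The series", "measured", "known", "first", "only" and "open" are said of these compounds alone.

Measured so far, all in a functional assay on HEK293 cells for antagonist activity at P2X purinoceptor 7 (Homo sapiens); a lower number here means a stronger inhibitor, a higher number a weaker inhibitor:
compound 1 `N#Cc1cccc(-c2ccc(Cl)c(C(=O)NCC3(O)CCCCCC3)c2)n1`, compound 1 gives 232 nM
compound 2 `O=C(NCC1(O)CCCCCC1)c1cc(-c2ccc(CO)cn2)ccc1Cl`, compound 2 gives 17 nM
compound 3 `O=C(NCC1(O)CCCC(F)(F)CC1)c1cc(-c2ncc(F)cn2)ccc1Cl`, compound 3 gives 46 nM

Compound 1 stands highest of the three numbers; compound 3 lies nearest to it and compound 2 furthest, both gaps beyond the scatter. Compound 4 `O=C(NCC1(O)CCCCCC1)c1cc(-c2ncc(F)cn2)ccc1Cl` is compound 1 with 5-fluoropyrimidin-2-yl in place of 6-cyanopyridin-2-yl on an aromatic carbon.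

Going by the values given here, one measured step bears on this change directly: a 14-fold lower number from compound 1 to compound 2 (1.14 log units; beyond the scatter), a large drop for swapping out the same leaving group for another pyridyl substituent. Among the compounds with values here, compound 3 carries the entering 5-fluoropyrimidin-2-yl group, though on a differently substituted alcohol ring, and with 46 nM its number sits well under that of compound 1; no single-place step connects compound 3 to compound 4, so only the two values can be compared. Taken together, a clear drop beyond the scatter is expected for compound 4, likely somewhat smaller than the step to compound 2.

The expected step is a 5.8-fold lower number from compound 1 to compound 4 (0.76 log units; beyond the scatter). Compound 4 is estimated at 40 nM, within 15 nM to 120 nM.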

Compound 4, half-maximal inhibitory concentration: 16 nM
Compound 4: the middle estimate sits 2.5-fold (0.40 log units) above what was measured, and the stated range covers the measured number.
By their numbers in this assay, from the lowest: compounds 4 and 2 (each within the scatter of the next); then compound 3; then compound 1.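

In this assay, this position on the aromatic carbon para to a chloro group accepts more than one replacement for 6-cyanopyridin-2-yl: 5-fluoropyrimidin-2-yl gives a 15-fold lower number from compound 1 to compound 4 (1.16 log units; beyond the scatter), a large step like the one seen with 5-(hydroxymethyl)pyridin-2-yl. The two replacements cannot be told apart, with a 1.1-fold lower number from compound 2 to compound 4 (0.03 log units; within the scatter), even though one is a pyridine ring bearing hydroxymethyl and the other a pyrimidine ring bearing fluorine. No measurement shown here accounts for either the large step or the lack of a difference between the two replacements.

Going by these compounds, it remains open whether the nitrile itself or the ring carrying it sets the higher number of compound 1. On these data alone, how an unsubstituted pyridin-2-yl or a 5-methoxypyrimidin-2-yl would behave at this position also remains open.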